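The compounds below may be only part of what the source reports. "The series", "measured", "known", "first", "only" and "open" are said of these compounds alone.

Compound 1 `Cc1cc(C)c(S(C)(=O)=O)cc1C(=O)N=C(N)N`: 11 nM
Compound 2 `CCCc1cc(C)c(C(=O)N=C(N)N)cc1S(C)(=O)=O`: 5.7 nM
Compound 3 `CCC(C)c1cc(C)c(C(=O)N=C(N)N)cc1S(C)(=O)=O`: 8 nM

All three were measured in a functional assay for inhibition of sodium/hydrogen exchanger (Oryctolagus cuniculus); on this read-out higher numbers stand for weaker inhibition and lower numbers for stronger inhibition. Compound 2 stands at the lowest of the three numbers, yet the steps of a 1.9-fold lower number from compound 1 to compound 2 (0.29 log units; within the scatter) and a 1.4-fold higher number from compound 2 to compound 3 (0.15 log units; within the scatter) both lie within the scatter, as does a 1.4-fold lower number from compound 1 to compound 3 (0.14 log units; within the scatter), so no order among the three can be claimed.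

Compound 4 `Cc1cc(Sc2ccncc2)c(S(C)(=O)=O)cc1C(=O)N=C(N)N` has not yet been measured. It differs from compound 2 in one place: (pyridin-4-yl)sulfanyl in place of propyl on an aromatic carbon. The measured steps that touch this aromatic carbon, a 1.9-fold lower number from compound 1 to compound 2 (0.29 log units; within the scatter) and a 1.4-fold higher number from compound 2 to compound 3 (0.15 log units; within the scatter), exchange one saturated chain for another and stay within the scatter, which shows that this position accepts some variation. Among the compounds with values here, none of them introduces a ring, a sulfur or hydrogen-bond acceptors, so no measured step bears directly on the present change, and the expectation rests on that tolerance alone, with a wide range. Compound 4 is therefore expected to give 9 nM in this assay, between 3 nM and 30 nM. The step of a 1.6-fold higher number from compound 2 to compound 4 (0.20 log units; within the scatter) is expected to stay near the scatter.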

Compound 4, half-maximal inhibitory concentration: 13 nM
Compound 4: the middle estimate sits 1.4-fold (0.16 log units) below what was measured; measured number inside the range.
By their numbers in this assay, from the lowest: compounds 2, 3, 1 and 4 (each within the scatter of the next, the first and the last beyond it).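

Compound 4 puts a ring, a sulfur and hydrogen-bond acceptors on the aromatic carbon ortho to the methylsulfonyl group, and in this assay this position still accepts them. Against the saturated chains the result depends on the comparison: replacing propyl gives a modest step beyond the scatter, a 2.3-fold higher number from compound 2 to compound 4 (0.36 log units; beyond the scatter), whereas replacing sec-butyl gives a 1.6-fold higher number from compound 3 to compound 4 (0.21 log units; within the scatter) and replacing methyl gives a 1.2-fold higher number from compound 1 to compound 4 (0.07 log units; within the scatter), both within the scatter. No supporting evidence bears on this result.

The compounds shown leave open whether the step from propyl belongs to the sulfur link or to the pyridin-4-yl part, which a phenylsulfanyl group or a pyridin-4-yl group bound directly to the aromatic carbon would separate. Going by these compounds, how an amine or a carboxylic acid would read at this position also remains open.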